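The source may report more compounds than this note shows. Statements on the series, on what has been measured and on what is new or still open speak of the compounds shown alone.

Of the compounds shown here, three sharing one core have been measured in a functional assay on the whole organism (B cells) with Mus musculus as the target; a higher number here means a larger maximal response, a lower number a smaller maximal response. Compound 1 `C=CCn1c(=O)n([C@@H]2O[C@H](CO)[C@H]3OC(CCC)(CCC)O[C@H]32)c2nc(N)nc(O)c21` gives 123% in this assay. Compound 3 `C=CCn1c(=O)n(C2C[C@H](O)C(CO)O2)c2nc(N)nc(O)c21` gives 99%. Compound 2 `Nc1nc(O)c2c(n1)n(C1OC(CO)[C@@H](O)[C@H]1O)c(=O)n2CC(O)CSc1ccccc1` gives only 12%, the lowest of the three numbers; the nearest, compound 3, lies well beyond the scatter above it, and compound 1 lies further still.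

Compound 4 `Nc1nc(O)c2c(n1)n(C1OC(CO)[C@@H](O)[C@H]1O)c(=O)n2Cc1ccc(Cl)cc1` has not yet been measured. It differs from compound 2 in one place: 4-chlorophenyl in place of 1-hydroxy-2-(phenylsulfanyl)ethyl on a saturated chain carbon bound to an aromatic nitrogen. For the measured compounds named here, no measured pair shows this exact change, so the size of the step can only be judged from the spread of the three known numbers. Because compound 2 gives 12% while both other measured compounds reach far larger maximal responses, the step in this assay is expected to go upward, beyond the scatter, though without reaching the level of compound 1. The estimate for compound 4 is 50%, within a range from 15% to 100%. That estimate means an expected step of a number 38 percentage points higher from compound 2 to compound 4 (beyond the scatter).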

Compound 4, largest response reached (reported as maximal response), in percent of the reference or control that the assay uses: 15%
Compound 4: middle estimate off by 35 percentage points, on the high side; the measured number falls inside the stated range.
By their numbers in this assay, from the lowest: compounds 2 and 4 (each within the scatter of the next); then compound 3; then compound 1.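

In this assay, replacing 1-hydroxy-2-(phenylsulfanyl)ethyl with 4-chlorophenyl on a saturated chain carbon bound to an aromatic nitrogen gives a number 3 percentage points higher from compound 2 to compound 4 (within the scatter), so the two compounds read alike. The group that leaves has 10 heavy atoms, including a sulfur, with a hydrogen-bond donor and acceptors, while the group that enters has 7 heavy atoms and neither donors nor acceptors, yet these differences do not separate the two numbers in this pair. No available measurement explains this match.

This single pair cannot show whether other groups at this place would also read alike, such as a plain phenyl, a longer alkyl chain, an amine or a carboxylic acid. It also leaves open how much of the low response depends on this place and how much on the rest of the molecule.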